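Oxime-ether flavone series: methoxy for fluoro on the aryl

The source may report more compounds than this note shows. Statements on the series, on what has been measured and on what is new or still open speak of the compounds shown alone.

Three compounds have been run in a functional assay on SK-HEP1 cells (Homo sapiens) for antiproliferative activity; a higher number here means a weaker inhibitor of growth, a lower number a stronger inhibitor of growth. Compound 1 `O=c1cc(-c2ccccc2)oc2cc(OC/C(=N/O)c3ccc(F)cc3)ccc12` gives 2300000 nM. Compound 2 `COc1ccc(/C(COc2ccc3c(=O)cc(-c4ccccc4)oc3c2)=N\O)cc1` gives 5600000 nM; it differs from compound 1 by methoxy in place of fluoro on an aromatic carbon, and this change made a 2.4-fold higher number from compound 1 to compound 2 (0.39 log units; beyond the scatter). Compound 3 `CO/N=C(/COc1ccc2c(=O)c(-c3ccccc3)coc2c1)c1ccc(F)cc1` gives 6100000 nM; the difference between the core of compound 3 and the core of compound 1 is not broken down here. The values of compound 3 and compound 2 lie within the scatter of each other, while compound 3 stands beyond the scatter from compound 1.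

Compound 4 `CO/N=C(/COc1ccc2c(=O)c(-c3ccccc3)coc2c1)c1ccc(OC)cc1` is not yet measured. It differs from compound 3 by methoxy in place of fluoro on an aromatic carbon, the same change already seen from compound 1 to compound 2, at the same place on the ring. Going by the values given here, on the single precedent of compound 1 to compound 2, the step from compound 3 to compound 4 is expected to be about a 2.3-fold higher number from compound 3 to compound 4 (0.36 log units; beyond the scatter), the same size and direction, with wide uncertainty because only one pair a 2.4-fold higher number from compound 1 to compound 2 (0.39 log units; beyond the scatter) supports it and the core differs. Compound 4 is therefore estimated at 14000000 nM in this assay, with a range from 6000000 nM to 35000000 nM.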

Compound 4, concentration for 50% growth inhibition: 5300000 nM
The estimate for compound 4 lay 2.6-fold (0.42 log units) above the measured number; measured number outside the range, below it.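

In this assay, methoxy in place of fluoro on the core of compound 3 gives a 1.2-fold lower number from compound 3 to compound 4 (0.06 log units; within the scatter), so the rise seen on the core of compound 1 does not carry over to this core. The two steps therefore cannot be treated as one transferable increment in this series: the same change on two cores in this assay, a 2.4-fold higher number (0.39 log units; beyond the scatter) from compound 1 to compound 2 and a 1.2-fold lower number (0.06 log units; within the scatter) from compound 3 to compound 4, 2.8-fold (0.45 log units) apart, beyond the scatter of two such steps

This shows that the outcome of the change from 4-fluorophenyl to 4-methoxyphenyl differs between these two cores, but it does not show which structural difference between the pairs is responsible, and each core is represented by a single pair.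

Still open, going by these compounds, is whether other groups in place of the fluoro, such as chloro, an amine or a carboxylic acid, would also give steps that differ between the two cores. Also open, on these data alone, is how a free oxime and its methyl ether compare when both sit on one and the same core.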